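Removing the chloro of compound 1: expected effect

The source may hold more compounds than are shown below. What is called first, only, known or untested is meant among the compounds shown, and "the series" means these compounds.

Compound 1 `O=C(O)c1cccc(C2=C(c3cc(Br)ccc3OCc3ccc(Cl)cc3)CCC2)c1` gives 12.6 nM in an assay on isolated protein for inhibition of prostaglandin E2 receptor EP1 subtype (Homo sapiens); a higher number here means a weaker inhibitor, a lower number a stronger inhibitor. Among the three compounds measured so far its number is the second highest. Its nearest neighbour is compound 2 `O=C(O)c1cncc(C2=C(c3cc(C(F)(F)F)ccc3OCc3ccccc3)CCC2)c1`, which in this assay gives 10 nM; the two values lie within the scatter, so nothing separates them. Furthest away is compound 3 `O=C(O)c1ccnc(C2=C(c3cc(Cl)ccc3OCc3ccccc3)CCC2)n1`, which in this assay gives 158 nM, a higher number beyond the scatter. For the measured compounds named here, compounds 2 and 3 each differ from compound 1 in more than one place, so no single-point step among the measured compounds can be read off.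

Compound 4 `O=C(O)c1cccc(C2=C(c3cc(Br)ccc3OCc3ccccc3)CCC2)c1` is the next compound to be measured. It differs from compound 1 in one place: hydrogen in place of chloro on an aromatic carbon, para to a large group; read one bond further out, the change is from (4-chlorobenzyl)oxy to benzyloxy. Going by the values given here, no measured pair shows this change, so its size is unknown. The change removes one heavy atom with no donor, no acceptor and no charge; a step of modest size is expected, if any, toward a somewhat higher number, probably within the scatter. Compound 4 is therefore expected to give about 22 nM in this assay, within 8 nM to 60 nM. The expected step is a 1.7-fold higher number from compound 1 to compound 4 (0.24 log units; within the scatter).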

Compound 4, half-maximal inhibitory concentration: 12.6 nM
The estimate for compound 4 lay 1.7-fold (0.24 log units) above the measured number; low and high end bracket the measured number.
By their numbers in this assay, from the lowest: compounds 2, 1 and 4 (each within the scatter of the next); then compound 3.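

In this assay, for the compounds shown here, the first single-point step reads no change at the digits printed from compound 1 to compound 4 (within the scatter), with hydrogen in place of chloro on an aromatic carbon, para to a large group. On this core, then, the chloro is not required for a number at this level: compound 4, with plain benzyloxy, gives 12.6 nM, and the two values cannot be told apart. Nothing available bears on why the chloro and the hydrogen read alike here.

Still open, from the compounds shown here alone, is whether this place tolerates groups generally, or only these two: an amine, a methoxy or a carboxylic acid at the same carbon would test that, as would a longer chain in place of the benzyl link. Also open is whether the step carries over to the cores of compound 2 and compound 3, which bear benzyloxy without the chloro but have no chloro-bearing partner among the compounds shown.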